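The source may report more compounds than this note shows. Statements on the series, on what has been measured and on what is new or still open speak of the compounds shown alone.

Two compounds of this series carry different groups on the carbonyl carbon of the shared core. Compound 1 `COc1cc2nc(N3CCN(C(=O)c4ccc(Br)o4)[C@H]4CCCC[C@H]43)nc(N)c2cc1OC` gives 7.53 in a functional assay on Vas deferens for antagonist activity at Alpha-1A adrenergic receptor (Rattus norvegicus); on this read-out higher numbers stand for higher potency (the scale is a negative logarithm) and lower numbers for lower potency. Compound 2 `COc1cc2nc(N3CCN(C(=O)c4cccs4)[C@H]4CCCC[C@H]43)nc(N)c2cc1OC` gives 7.44 in this assay. Within the data shown here, the one step between them, a number 0.09 log units lower from compound 1 to compound 2 (within the scatter), is within the scatter, so the two numbers are not told apart by this read-out, and compound 2 stands within the scatter of compound 1, the only other number available.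

Compound 3 `COc1cc2nc(N3CCN(C(=O)c4ccccn4)[C@H]4CCCC[C@H]43)nc(N)c2cc1OC` is not yet measured. It differs from compound 2 by pyridin-2-yl in place of thiophen-2-yl on a carbonyl carbon. Among the measured compounds shown here, the only measured step that bears on this change is the one at the same place, a number 0.09 log units lower from compound 1 to compound 2 (within the scatter), where exchanging one five-membered aromatic group for another left the number within the scatter. For the measured compounds named here, no measured compound carries a six-membered ring at this position, so the bearing is indirect. The expected step is a number 0.04 log units lower from compound 2 to compound 3 (within the scatter), that is, none beyond the scatter. Compound 3 is therefore estimated at 7.4 in this assay, with an expected range from 6.9 to 7.9.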

Compound 3, negative logarithm of the antagonist equilibrium constant: 7.04
The estimate for compound 3 lay 0.36 log units above the measured number, within the range that was stated.
By their numbers in this assay, from the lowest: compound 3; then compounds 2 and 1 (each within the scatter of the next).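

The carbonyl carbon is not indifferent to the aromatic group it carries. In this assay, the exchange of a five-membered aromatic ring for a six-membered one gives a step beyond the scatter (a number 0.40 log units lower from compound 2 to compound 3 (beyond the scatter)), whereas the exchange between the two five-membered groups stayed within it (a number 0.09 log units lower from compound 1 to compound 2 (within the scatter)). The comparison with the 5-bromofuran-2-yl group points the same way (a number 0.49 log units lower from compound 1 to compound 3 (beyond the scatter)), so among these three compounds, the pyridin-2-yl group is the only one that separates from the others, though both steps are modest, and no measurement offered here accounts for the difference.

In the step to pyridin-2-yl, ring size and the hetero atom change together, and the compounds shown do not separate the two. As far as these compounds go, how an unsubstituted phenyl ring, a furan-2-yl group without the bromine, a pyridin-3-yl group or a simple alkyl chain on the carbonyl carbon would read remains open.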